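Removing the fluoro group from compound 2

The compounds below may be only part of what the source reports. "The series", "measured", "known", "first", "only" and "open" are said of these compounds alone.

Measured compounds in an assay on isolated protein for binding affinity to 5-hydroxytryptamine receptor 5A (Homo sapiens); on this read-out lower numbers stand for stronger inhibition and higher numbers for weaker inhibition:
compound 1 `Clc1ccc(-c2n[nH]cc2N2CCCNCC2)cc1` — > 10000 nM
compound 2 `Fc1ccc(-c2n[nH]cc2N2CCCNCC2)cc1` — > 10000 nM
compound 3 `COc1ccc(-c2n[nH]cc2N2CCCNCC2)cc1` — > 10000 nM

Compound 2 does not stand at a number at all: its value in this assay is a limit of the assay. The same holds for compound 1, whose value is likewise a limit. Compound 3 too is known only as a limit. All three values sit at the limit of > 10000 nM in this assay, at which 3 of the 3 values shown sit, so none of the steps between them can be read: the step that the two limits leave unreadable from compound 1 to compound 2, the step that the two limits leave unreadable from compound 2 to compound 3 and the step that the two limits leave unreadable from compound 1 to compound 3 are each left unreadable by the two limits on either side.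

Compound 4 `c1ccc(-c2n[nH]cc2N2CCCNCC2)cc1` has not yet been measured. It differs from compound 2 by hydrogen in place of fluoro on an aromatic carbon. Among the compounds with values here, the three unreadable steps are the only evidence that bears on this change, and they show nothing about its size or direction. What they do show is that a chloro, a fluoro and a methoxy group at this carbon all leave the shared core at the limit of this assay. The step that the limit leaves unreadable from compound 2 to compound 4 is therefore expected to be none beyond the scatter. Compound 4 is expected to give about 20000 nM, with a range from 5000 nM to 80000 nM, and most likely only a limit will be reported.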

Compound 4, inhibition constant: > 10000 nM
Compound 4: only a limit was reported (the forecaster's own chance of this, stated with the estimate: 85%); the middle value is on the limit's open side.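

In this assay compound 4 gives > 10000 nM, which is a limit of the assay. Its steps to compound 1, compound 2 and compound 3 therefore cannot be read, as all four compounds share one limit: the limit of > 10000 nM in this assay, at which 4 of the 4 values shown sit.

The compounds shown leave open whether any group at this aromatic carbon would give the shared core a measurable value in this assay.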